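A formyl in place of hydroxy on compound 2

The source may report more compounds than this note shows. Statements on the series, on what has been measured and on what is new or still open speak of the compounds shown alone.

Of the compounds shown here, three sharing a core have been measured in a functional assay on COLO 205 cells (Homo sapiens) for inhibition, read by MTT assay, with a stated time of 48 h; a lower number here means a stronger inhibitor, a higher number a weaker inhibitor. Compound 1 (`COc1ccc(/C=C/C(=O)c2cc(OC)c(OC)c(OC)c2)c(OC)c1`) gives 82500 nM. Compound 3 (`COc1cc(C(=O)/C=C/c2cc([N+](=O)[O-])ccc2O)cc(OC)c1OC`) gives 76000 nM. Compound 2 (`COc1cc(C(=O)/C=C/c2cccc(O)c2)cc(OC)c1OC`) gives 49000 nM, a number within the scatter of both others, so no order can be read among the three.

Compound 4 (`COc1cc(C(=O)/C=C/c2cccc(C=O)c2)cc(OC)c1OC`) has not yet been measured. It differs from compound 2 in one place, with formyl in place of hydroxy on an aromatic carbon, meta to a large group (formyl in place of hydroxy on an aromatic carbon). The 3-hydroxyphenyl of compound 2 thus becomes the 3-formylphenyl of compound 4. Going by the values given here, no two measured compounds differ in only one place, so the data offer no direct precedent for this change. No step beyond the scatter is expected in this assay, in either direction. That expectation rests on compound 3 at 76000 nM, which stays within the scatter of compound 2 at 49000 nM although the two differ in more than one place. The estimated change is small, a 1.1-fold higher number from compound 2 to compound 4 (0.05 log units; within the scatter). For compound 4 the expected value is 55000 nM, with an estimated range from 25000 nM to 120000 nM.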

Compound 4, half-maximal inhibitory concentration: 22500 nM
Beside the measured number, compound 4's estimate is 2.4-fold (0.39 log units) above it; the measured number lies below the stated range.
By their numbers in this assay, from the lowest: compound 4; then compounds 2, 3 and 1 (each within the scatter of the next).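

In this assay, going by these compounds alone, putting formyl in place of hydroxy gives a 2.2-fold lower number from compound 2 to compound 4 (0.34 log units; beyond the scatter) and is the first change in this set confined to one place. Its step lies beyond the scatter, so the aromatic carbon meta to a large group is not indifferent to the group it carries. The change also need not cost activity: by the computed count, the 3-formylphenyl of compound 4 has lost the hydrogen-bond donor of the 3-hydroxyphenyl of compound 2 and kept a hydrogen-bond acceptor, yet the number is lower, though this is a modest step resting on a single pair of compounds, and nothing measured here accounts for it.

Going by these compounds, whether the lower number belongs to the formyl itself or follows from the departure of the hydroxy remains open, and a hydroxymethyl or a carboxylic acid on the same aromatic carbon would help to separate the two. On these data alone, it is also open whether the same exchange would give a similar step on the other compounds, such as compound 3, whose hydroxy stands in a different setting.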